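Methyl to cyclopropyl on the shared core

A few compounds are considered here, and "the series" means these few. Any claim that something is new, unique, unknown or untested is made for them only; others in the source may bear on it.

In a functional assay on DU-145 cells (Homo sapiens) for antiproliferative activity, read by sulforhodamine B assay, with a stated time of 48 h (on this read-out lower numbers stand for stronger inhibition of growth and higher numbers for weaker inhibition of growth), compound 3 `CNc1nc(Nc2ccc(OC)cc2)nc2ccccc12` gives 14300 nM. Compound 1 `COc1ccc(Nc2nc(NC3CCCC3)c3ccccc3n2)cc1` gives 12400 nM, and the swap of cyclopentyl for methyl makes a 1.2-fold higher number from compound 1 to compound 3 (0.06 log units; within the scatter), so these two stand level. Compound 2 `CCCNc1nc(Nc2ccc(OC)cc2)nc2ccccc12` gives 4080 nM, the lowest number of the three and so the strongest growth inhibition.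

Compound 4 `COc1ccc(Nc2nc(NC3CC3)c3ccccc3n2)cc1` has cyclopropyl in place of methyl on a nitrogen on an aromatic ring.

For the measured compounds named here, two measured steps bear on this change. Moving to the methyl of compound 3 from the propyl of compound 2 gives a 3.5-fold higher number from compound 2 to compound 3 (0.54 log units; beyond the scatter), so a longer group can help. Yet compound 1 goes against any simple rule that a larger group lowers the number, since its cyclopentyl ring matches methyl, and propyl beats cyclopentyl with a 3.0-fold lower number from compound 1 to compound 2 (0.48 log units; beyond the scatter). Cyclopropyl is also a ring, so compound 4 could fall anywhere in this span.

A modest fall is expected, with an estimated 1.8-fold lower number from compound 3 to compound 4 (0.25 log units; within the scatter). For compound 4 the estimated value is 8000 nM, with an expected range from 3500 nM to 16000 nM.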

Compound 4, concentration for 50% growth inhibition: 13000 nM
The estimate for compound 4 lay 1.6-fold (0.21 log units) below the measured number; the range from low to high includes it.
By their numbers in this assay, from the lowest: compound 2; then compounds 1, 4 and 3 (each within the scatter of the next).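

In this assay, cyclopropyl in place of methyl on this nitrogen leaves the number level (a 1.1-fold lower number from compound 3 to compound 4 (0.04 log units; within the scatter)), and cyclopropyl also stands level with cyclopentyl (a 1.0-fold higher number from compound 1 to compound 4 (0.02 log units; within the scatter)). Propyl alone stands apart (a 3.2-fold higher number from compound 2 to compound 4 (0.50 log units; beyond the scatter)), so a small ring gives no gain here, and a ring of either size behaves like methyl rather than like propyl. Nothing available here explains why propyl differs from the other three groups.

Open chains do not share one behaviour, as methyl in compound 3 stays level with the rings, so the gain cannot yet be tied to chain length alone. An ethyl or butyl chain would show whether the number keeps falling past propyl, and a branched isopropyl group would test the shape of the chain.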